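The source may report more compounds than this note shows. Statements on the series, on what has been measured and on what is new or still open speak of the compounds shown alone.

Measured so far in a functional assay on MDA-MB-231 cells (Homo sapiens) for antiproliferative activity, read by MTT assay, with a stated time of 48 h; a higher number here means a weaker inhibitor, a lower number a stronger inhibitor:
compound 1 `C/C(=C\CC/C(C)=C/CC[C@@H]1[C@@]2(C)CCC(=O)C(C)(C)[C@H]2CC[C@@]1(C)O)CC/C=C(\C)C(=O)OCc1cn(-c2ccccc2Br)nn1`: > 150000 nM (a limit)
compound 2 `C/C(=C\CC/C(C)=C/CC[C@@H]1[C@@]2(C)CCC(=O)C(C)(C)[C@H]2CC[C@@]1(C)O)CC/C=C(\C)C(=O)OCc1cn(-c2cccc(Cl)c2)nn1`: 103000 nM
compound 3 `C/C(=C\CC/C(C)=C/CC[C@@H]1[C@@]2(C)CCC(=O)C(C)(C)[C@H]2CC[C@@]1(C)O)CC/C=C(\C)C(=O)OCc1cn(C[C@@H]2O[C@H](n3ccc(=O)[nH]c3=O)[C@H]3OC(C)(C)O[C@H]32)nn1`: > 150000 nM (a limit)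

Compound 1 gives > 150000 nM, which is a limit of the assay and not a number. Compound 1 therefore has no exact place in the series and sits at the limit of > 150000 nM in this assay, at which 2 of the 3 values shown sit.

Compound 4 `C/C(=C\CC/C(C)=C/CC[C@@H]1[C@@]2(C)CCC(=O)C(C)(C)[C@H]2CC[C@@]1(C)O)CC/C=C(\C)C(=O)OCc1cn(-c2ccccc2Cl)nn1` keeps the rest of compound 1 and carries 2-chlorophenyl in place of 2-bromophenyl: chloro in place of bromo on an aromatic carbon. The change is chloro in place of bromo on an aromatic carbon, ortho to a large group.

For the measured compounds named here, the one measured step that bears on this is an at least 1.4-fold lower number from compound 1 to compound 2 (0.16 log units; that floor lies within the scatter). That step swaps the halogen and moves it as well, as 3-chlorophenyl replaces 2-bromophenyl, and it starts from a limit, so it fixes no size for the present change. Compound 3 has no halogen-bearing aryl group and adds nothing on this swap.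

No step beyond the scatter is therefore expected in this assay, and no direction can be given with confidence. The expected step is an at least 1.0-fold lower number from compound 1 to compound 4 (0.02 log units; that floor lies within the scatter). Compound 4 is estimated at 140000 nM. The estimated range for compound 4 runs from 80000 nM to 250000 nM, and a report of only a limit is also expected to be quite possible.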

Compound 4, half-maximal inhibitory concentration: > 150000 nM
Compound 4 ended at the assay's limit; the forecaster's own chance of this, stated with the estimate: 50%; middle value at least 1.0-fold (0.02 log units) away from the limit.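

In this assay compound 4 gives > 150000 nM, a limit of the assay and not a number, so chloro in place of bromo on this aromatic carbon, ortho to a large group, adds no measurable value to the series, and the step from the bromo compound cannot be read, with both ends being limits. The comparison with the 3-chlorophenyl compound keeps the halogen fixed and changes only its place, giving an at least 1.4-fold higher number from compound 2 to compound 4 (0.16 log units; that floor lies within the scatter); with that floor inside the scatter, no effect of the place can be claimed. Most of the series now rests at one limit: the limit of > 150000 nM in this assay, at which 3 of the 4 values shown sit.

Still open, from the compounds shown here alone, is whether any change to this aryl group can bring the series to a measured value clearly apart from compound 2, or whether the 2-chlorophenyl and 3-chlorophenyl groups truly differ by more than the scatter. An amine or a carboxylic acid in place of the halogen would test whether this end of the molecule moves the read-out at all, or whether the level stays the same across the shared core.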